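This account rests on a few compounds, and the source may have more. Where it says the series, first, only, none or still open, it means among the compounds named here.

The measured compounds in an ADME assay on HUVEC cells (Homo sapiens) for antiproliferative activity, read by MTT assay, with a stated time of 48 h; on this read-out higher numbers stand for weaker inhibition and lower numbers for stronger inhibition:

Compound 1, `Cc1cccc(-n2nncc2CN2C(=O)C3(C(C#N)=C(N)Oc4c(N)cc5nc6ccccc6nc5c43)c3ccccc32)c1`, gives > 50000 nM, which is a limit of the assay.
Compound 2, `N#CC1=C(N)Oc2c(N)cc3nc4ccccc4nc3c2C12C(=O)N(Cc1cnnn1-c1ccccc1Cl)c1ccccc12`, gives > 50000 nM, also a limit.
Compound 3, `N#CC1=C(N)Oc2c(N)cc3nc4ccccc4nc3c2C12C(=O)N(Cc1cnnn1-c1cccc(C(F)(F)F)c1)c1ccccc12`, gives > 50000 nM, again a limit.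

Compound 3 therefore stands at the limit of this assay, and the evidence is uniform: the limit of > 50000 nM in this assay, at which 3 of the 3 values shown sit. Because every value is a limit, the steps between the three compounds cannot be read in size or direction: a step that the two limits leave unreadable from compound 1 to compound 2, a step that the two limits leave unreadable from compound 1 to compound 3 and a step that the two limits leave unreadable from compound 2 to compound 3.

Compound 4, `Cc1ccc(-n2nncc2CN2C(=O)C3(C(C#N)=C(N)Oc4c(N)cc5nc6ccccc6nc5c43)c3ccccc32)cc1C`, differs from compound 3 in one place: 3,4-dimethylphenyl in place of 3-(trifluoromethyl)phenyl on an aromatic nitrogen. Within the data shown here, the steps that bear on this change are the three exchanges of the aryl group on the same aromatic nitrogen of the shared core, and each of them is unreadable, so they give no size and no direction for the step to compound 4. What they do show is that three different aryl groups at this position all left the compounds at the limit of this assay.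

Compound 4 is accordingly expected to sit at the limit as well, with an estimate of 70000 nM and a range from 20000 nM to 250000 nM. The step from compound 3 is expected to be a step that the limit leaves unreadable from compound 3 to compound 4, not beyond the scatter.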

Compound 4, half-maximal inhibitory concentration: > 50000 nM
Compound 4: no number, only a limit (the forecaster's own chance of this, stated with the estimate: 85%); the middle value is on the limit's open side.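

Compound 4 also gives only a limit, so its steps to compound 1, compound 2 and compound 3 cannot be read in size or direction. The picture in this assay remains uniform: the limit of > 50000 nM in this assay, at which 4 of the 4 values shown sit. The compounds shown leave open the actual value of each compound, and whether any other aryl group on this aromatic nitrogen would give a readable number.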